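The compounds below may be only part of what the source reports. "The series", "measured", "known", "first", "only" and "open" are said of these compounds alone.

Measured compounds in a functional assay on SNB-75 cells (Homo sapiens) for inhibition, read by sulforhodamine B assay, with a stated time of 48 h, tested at 10 uM; on this read-out higher numbers stand for a weaker effect at the one concentration tested and lower numbers for a stronger effect:
- compound 1 `O=C(Nc1cccc(-n2cc(-c3ccncc3)c(-c3cc(O)cc(Cl)c3)n2)c1)Nc1ccc(Cl)c(C(F)(F)F)c1` gives 24.1%
- compound 2 `COc1cc(Cl)cc(-c2nn(-c3cccc(NC(=O)Nc4ccc(Cl)c(C(F)(F)F)c4)c3)cc2-c2ccncc2)c1` gives 14.5%
- compound 3 `COc1cc(Cl)cc(-c2nn(-c3cccc(NC(=O)Nc4cc(C(F)(F)F)cc(C(F)(F)F)c4)c3)cc2-c2ccncc2)c1` gives 11.3%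

Compound 2 sits among these three numbers: the step of a number 9.6 percentage points lower from compound 1 to compound 2 (within the scatter) is within the scatter, and the value of compound 3 in this assay lies close to that of compound 2, again within the scatter. On the numbers shown, the three compounds cannot be told apart.

Compound 4 `COc1cc(Cl)cc(-c2nn(-c3cccc(NC(=O)c4cccc(C(F)(F)F)c4)c3)cc2-c2ccncc2)c1` has not been measured. It differs from compound 2 by 3-(trifluoromethyl)phenyl in place of (4-chloro-3-(trifluoromethyl)phenyl)amino on a carbonyl carbon. Among the measured compounds shown here, the only measured step, from compound 1 to compound 2, concerns a methyl in place of hydrogen on an oxygen on an aromatic ring and was within the scatter; it touches a different part of the molecule and gives no guide to the exchange at the carbonyl carbon. For the measured compounds named here, no measured pair shows what happens when the (4-chloro-3-(trifluoromethyl)phenyl)amino group leaves and 3-(trifluoromethyl)phenyl enters.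

With nothing in the data to anchor the change, compound 4 is estimated to give 35% in this assay, in a range from 10% to 70%. The expected step of a number 20.5 percentage points higher from compound 2 to compound 4 (beyond the scatter) is therefore toward a weaker effect, but with wide uncertainty.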

Compound 4, a percentage reported as activity, at one concentration (the size of the read-out at that concentration, not a potency): 53.9%
Beside the measured number, compound 4's estimate is 18.9 percentage points below it, and the stated range covers the measured number.
By their numbers in this assay, from the lowest: compounds 3, 2 and 1 (each within the scatter of the next, the first and the last beyond it); then compound 4.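

In this assay, putting 3-(trifluoromethyl)phenyl in place of (4-chloro-3-(trifluoromethyl)phenyl)amino on the carbonyl carbon gives a number 39.4 percentage points higher from compound 2 to compound 4 (beyond the scatter), so this is the first single exchange among the compounds shown that moves the read-out beyond the scatter, and it moves it toward a weaker effect at the one concentration tested. The result therefore marks this carbonyl carbon substituent as a place where the effect on these cells does not hold up under change, whereas the methyl on the oxygen did not separate compound 1 from compound 2. Nothing measured here explains why the effect weakens at this position.

The exchange removes the amino nitrogen, with its hydrogen-bond donor, and the chlorine in one step, so the compounds shown do not say which of the two losses accounts for the weaker effect. On these data alone, a compound with (3-(trifluoromethyl)phenyl)amino on that carbonyl carbon, or one with 4-chloro-3-(trifluoromethyl)phenyl there, would separate the two, and whether either restores the effect remains open.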